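Replacing the anilino group of compound 3 with pyrrolidin-1-yl

The source may hold more compounds than are shown below. What is called first, only, known or untested is meant among the compounds shown, and "the series" means these compounds.

Compound 3 `O=C1C=C(Nc2ccccc2)C(=O)c2c1nc1n2[C@H]2OC[C@@H](O)[C@H]2OC1` gives 4970 nM in a functional assay on ECa-109 cells for inhibition, with ECa-109 cell line (Homo sapiens) as the target, read by sulforhodamine B assay; a higher number here means a weaker inhibitor, a lower number a stronger inhibitor. Its companions compound 1 `COc1cccc(NC2=CC(=O)c3c(nc4n3[C@H]3OC[C@@H](O)[C@H]3OC4)C2=O)c1` with 3340 nM and compound 2 `O=C1C(Nc2cccc(Cl)c2)=CC(=O)c2c1nc1n2[C@H]2OC[C@@H](O)[C@H]2OC1` with 3080 nM lie within the scatter of it, so the three cannot be ranked. Compound 4 `O=C1C=C(N2CCCC2)C(=O)c2c1nc1n2[C@H]2OC[C@@H](O)[C@H]2OC1` differs from compound 3 by pyrrolidin-1-yl in place of anilino on a double-bonded ring carbon. For the measured compounds named here, the only measured step, a 1.1-fold lower number from compound 1 to compound 2 (0.04 log units; within the scatter), exchanges a substituent on the aromatic ring that is removed altogether here and so does not speak to the exchange of the anilino itself; no step in this set covers a change of this kind. Compound 4 is therefore expected to stay close to compound 3, the estimated step being a 1.1-fold higher number from compound 3 to compound 4 (0.04 log units; within the scatter). The estimate for compound 4 is 5500 nM, with a range from 1600 nM to 18000 nM.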

Compound 4, half-maximal inhibitory concentration: > 16000 nM
Compound 4: no number, only a limit; the forecaster's own chance of this, stated with the estimate: 10%; middle value at least 2.9-fold (0.46 log units) away from the limit.
By their numbers in this assay, from the lowest: compounds 2, 1 and 3 (each within the scatter of the next). At a limit, above all of these: compound 4.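

For the compounds shown here, exchanging the anilino group on this double-bonded ring carbon produces the first change in the set that lies beyond the scatter (an at least 3.2-fold higher number from compound 3 to compound 4 (0.50 log units; beyond the scatter)), whereas the substituent exchange on the aromatic ring of the anilino group stayed within it (a 1.1-fold lower number from compound 1 to compound 2 (0.04 log units; within the scatter)). In this assay, compound 4 gives only a limit (> 16000 nM), not a number: the limit of > 16000 nM in this assay, at which 1 of the 4 values shown sits.

The exchange removes the aromatic ring and the hydrogen-bond donor together, and the compounds shown do not separate the two. Cyclohexylamino, which keeps the amine hydrogen without the aromatic ring, and methylanilino, which keeps the aromatic ring without that hydrogen, remain open at this carbon.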